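The source may report more compounds than this note shows. Statements on the series, on what has been measured and on what is new or still open speak of the compounds shown alone.

Compound 3 `CCOC(=O)C1=C(N/N=C(/C(C)=O)C(=O)OCC)Nc2[nH]nc(C)c2C1c1ccc(N(C)C)cc1` stands at the floor of a functional assay on HeLa cells (Homo sapiens) for inhibition, read by MTT assay, with a stated time of 48 h; on this read-out lower numbers stand for stronger inhibition and higher numbers for weaker inhibition: in this assay compound 3 gives only > 100000 nM, which is a limit rather than a number. Compound 1 `CCOC(=O)C1=C(N/C=N/c2ccc([N+](=O)[O-])cc2)Nc2[nH]nc(C)c2C1c1ccc(N(C)C)cc1` gives 57800 nM and compound 2 `CCOC(=O)C1=C(N/N=C(/Cl)C#N)Nc2[nH]nc(C)c2C1c1ccc(N(C)C)cc1` gives 26200 nM. Both steps toward compound 3, an at least 1.7-fold higher number from compound 1 to compound 3 (0.23 log units; that floor lies within the scatter) and an at least 3.8-fold higher number from compound 2 to compound 3 (0.58 log units; beyond the scatter), ran toward weaker inhibition. Compound 4 `CCOC(=O)C(=NNC1=C(C(=O)OCC)C(c2ccc(N(C)C)cc2)c2c(C)n[nH]c2N1)C(=O)OCC` carries the change (a group of 12 heavy atoms (7 carbon, 1 nitrogen, 4 oxygen; no ring) in place of a group of 10 heavy atoms (6 carbon, 1 nitrogen, 3 oxygen; no ring), on an amine nitrogen). Compound 3 already sits at the limit of > 100000 nM in this assay, at which 1 of the 3 values shown sits, so a further growth of the same acyclic substituent gives no ground to expect a return to measurable inhibition. The estimated step that the limit leaves unreadable from compound 3 to compound 4 is expected to stay within the scatter. Compound 4 is therefore expected to give about 150000 nM, between 60000 nM and 400000 nM, most likely again reported as a limit.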

Compound 4, half-maximal inhibitory concentration: 83800 nM
The estimate for compound 4 lay 1.8-fold (0.25 log units) above the measured number; the range from low to high includes it.
By their numbers in this assay, from the lowest: compound 2; then compounds 1 and 4 (each within the scatter of the next). At a limit, above all of these: compound 3.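

Compound 4 shows that a group with no ring on this amine nitrogen can still give a measured number in this assay, which compound 3 did not show. Against the ring-bearing group the result is a 1.4-fold higher number from compound 1 to compound 4 (0.16 log units; within the scatter), so the two groups do not separate, while against the smaller chlorine-bearing group it is a 3.2-fold higher number from compound 2 to compound 4 (0.50 log units; beyond the scatter), which means weaker inhibition. The remaining step, an at least 1.1-fold lower number from compound 3 to compound 4 (0.07 log units; that floor lies within the scatter), is only a floor. It is a floor because compound 3 gives only a limit: the limit of > 100000 nM in this assay, at which 1 of the 4 values shown sits.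

The compounds shown leave open whether a carboxylic acid or an amide in place of the ethyl esters would shift the number. They also leave open what a longer chain on this nitrogen would do.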